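The source may hold more compounds than are shown below. What is called first, only, known or untested is meant among the compounds shown, and "the series" means these compounds.

In an ADME assay on Jurkat cells (Homo sapiens) for cytotoxicity, read by XTT assay (a higher number here means that more compound is tolerated, a lower number that less compound is tolerated), compound 1 (`N#CCC(=O)c1cccc(I)c1`) has the entry "not determined" (no result reported) and so offers no number to start from. In this assay, among the measured compounds shown here, compound 2 (`N#CCC(=O)c1cccc(C(=O)c2ccccc2)c1`) gives 251000 nM and compound 3 (`N#CCC(=O)c1cccc(-c2ccccc2)c1`) gives 233000 nM and these two values lie within the usual scatter of each other and are the only numerical guide. Compound 4 (`NC(=O)CC(=O)c1cccc(I)c1`) has not yet been measured. It differs from compound 1 by carbamoyl in place of cyano on a saturated chain carbon bound to a carbonyl carbon. For the measured compounds named here, no measured pair shows this change, and no step beyond the scatter is expected from it in this assay in either direction. For compound 4 the estimated half-maximal cytotoxic concentration is 240000 nM (110000 nM to 500000 nM).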

Compound 4, half-maximal cytotoxic concentration: > 312000 nM
Compound 4 was reported as a limit; the forecaster's own chance of this, stated with the estimate: 25%; at least 1.3-fold (0.11 log units) between middle value and limit.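

Among the compounds shown here, no step from compound 1 to compound 4 can be read, and the result for compound 4 is only a limit: the limit of > 312000 nM in this assay, at which 1 of the 4 values shown sits.

In this assay the compounds shown leave open what carbamoyl in place of cyano does to the tolerated concentration.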